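Aryl change on the sulfonamide nitrogen: tert-butyl to chloro

The source may report more compounds than this note shows. Statements on the series, on what has been measured and on what is new or still open speak of the compounds shown alone.

Measured in a functional assay on K562 cells (Homo sapiens) for inhibition, read by CCK-8 assay, with a stated time of 72 h; on this read-out higher numbers stand for weaker inhibition and lower numbers for stronger inhibition:
- compound 1 `Cc1ccc(C)c(NS(=O)(=O)c2cccc(CCCCCCNC(=O)/C=C/c3cccnc3)c2)c1`: 0.84 nM
- compound 2 `CC(C)(C)c1ccc(NS(=O)(=O)c2cccc(CCCCCCNC(=O)/C=C/c3cccnc3)c2)cc1`: 24.7 nM

Of the two numbers, the higher belongs to compound 2 at 24.7 nM. Compound 3 `O=C(/C=C/c1cccnc1)NCCCCCCc1cccc(S(=O)(=O)Nc2ccc(Cl)cc2)c1` has chloro in place of tert-butyl on an aromatic carbon, para to a large group, and the rest of the molecule is unchanged: chloro in place of tert-butyl on an aromatic carbon. Put another way, 4-(tert-butyl)phenyl becomes 4-chlorophenyl.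

For the measured compounds named here, only one measured step bears on this change: a 29-fold higher number from compound 1 to compound 2 (1.47 log units; beyond the scatter). There, 4-(tert-butyl)phenyl replaced 2,5-dimethylphenyl on a sulfonamide nitrogen, and the step was large and beyond the scatter. It shows that this aryl group can move the number strongly in this assay. Going by the values given here, no measured compound carries chloro, however, so the evidence is a single step. Losing tert-butyl is expected to give a lower number, through a step smaller than the measured one, and a change within the scatter cannot be excluded. The estimate corresponds to a 4.9-fold lower number from compound 2 to compound 3 (0.69 log units; beyond the scatter), as an expected shift. For compound 3 the estimated value is 5 nM, with an expected range of 1 nM to 25 nM.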

Compound 3, half-maximal inhibitory concentration: 6.41 nM
Compound 3: middle estimate off by 1.3-fold (0.11 log units), on the low side, within the range that was stated.
By their numbers in this assay, from the lowest: compound 1; then compound 3; then compound 2.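

In this assay, the aryl ring stays in place and only the group on this aromatic carbon changes, and the number still moves: a 3.9-fold lower number from compound 2 to compound 3 (0.59 log units; beyond the scatter). Part of the gap between the first two compounds therefore goes with tert-butyl itself and can be narrowed by a group of a single heavy atom. The earlier step could not give this reading. That step also changed the substitution pattern of the ring. The 4-chlorophenyl group still does not match the 2,5-dimethylphenyl group, with a 7.6-fold higher number from compound 1 to compound 3 (0.88 log units; beyond the scatter), so compound 1 keeps the lowest number of the three at 0.84 nM, and nothing at hand gives a reason for either step.

Still open, on these data alone, is whether a single methyl of the 2,5-dimethylphenyl group is enough to keep the low number of compound 1, or whether both are needed. Also open, as far as these compounds go, is how a methoxy group, a fluorine atom or a carboxylic acid would compare with chloro on the same aromatic carbon, and whether the order of these aryl groups holds with a shorter or longer chain than the hexyl linker.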